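From a Saturated Ring to a Methylated Cyclohexene

This account rests on a few compounds, and the source may have more. Where it says the series, first, only, none or still open, it means among the compounds named here.

Three measured compounds share one core and differ only in the group on an aromatic carbon. Compound 1 `CCCc1nc(C(F)(F)F)ccc1CNC(=O)C(C)c1ccc(NS(C)(=O)=O)c(F)c1` carries a propyl there, and in an assay on CHO cells for antagonist activity at transient receptor potential cation channel subfamily V member 1 (Homo sapiens), read by FLIPR and calcium flux (on this read-out lower numbers stand for stronger inhibition and higher numbers for weaker inhibition), compound 1 gives 22.7 nM. Compound 2 `CCCCCCc1nc(C(F)(F)F)ccc1CNC(=O)C(C)c1ccc(NS(C)(=O)=O)c(F)c1` carries a hexyl, and in this assay compound 2 gives 1.6 nM. Compound 3 `CCC1CCC(c2nc(C(F)(F)F)ccc2CNC(=O)C(C)c2ccc(NS(C)(=O)=O)c(F)c2)CC1` carries a 4-ethylcyclohexyl, and in this assay compound 3 gives 0.3 nM, the lowest of the three numbers. The steps were a 14-fold lower number from compound 1 to compound 2 (1.15 log units; beyond the scatter), a 76-fold lower number from compound 1 to compound 3 (1.88 log units; beyond the scatter) and a 5.3-fold lower number from compound 2 to compound 3 (0.73 log units; beyond the scatter).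

Compound 4 `CC1C=C(c2nc(C(F)(F)F)ccc2CNC(=O)C(C)c2ccc(NS(C)(=O)=O)c(F)c2)CCC1` is the next variation at the same aromatic carbon: 3-methylcyclohex-1-en-1-yl in place of 4-ethylcyclohexyl on an aromatic carbon. The two steps that bear on it, a 76-fold lower number from compound 1 to compound 3 (1.88 log units; beyond the scatter) and a 5.3-fold lower number from compound 2 to compound 3 (0.73 log units; beyond the scatter), both show that a six-membered ring at this position gave lower numbers than a chain. Among the measured compounds shown here, compound 4 keeps a six-membered ring but with a double bond and one carbon fewer, a change no measured pair covers directly, so only a small step is expected, a 2.0-fold higher number from compound 3 to compound 4 (0.30 log units; within the scatter), toward a slightly higher number. Compound 4 is therefore estimated at 0.6 nM, within a range from 0.15 nM to 2.5 nM.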

Compound 4, inhibition constant: 0.2 nM
Compound 4: middle estimate off by 3.0-fold (0.48 log units), on the high side, and the stated range covers the measured number.
By their numbers in this assay, from the lowest: compounds 4 and 3 (each within the scatter of the next); then compound 2; then compound 1.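

In this assay the change from 4-ethylcyclohexyl to 3-methylcyclohex-1-en-1-yl gives a 1.5-fold lower number from compound 3 to compound 4 (0.18 log units; within the scatter) and so leaves compound 3 and compound 4 level, even with a double bond entering the ring and the group holding one carbon fewer. The chains stay well apart from this new ring, with an 8.0-fold lower number from compound 2 to compound 4 (0.90 log units; beyond the scatter) and a 110-fold lower number from compound 1 to compound 4 (2.05 log units; beyond the scatter) showing that, among these four compounds, both six-membered rings give lower numbers than either chain. No evidence is available to explain why the saturated and unsaturated rings read alike.

The double bond and the change of ring substituent arrive together between compound 3 and compound 4, so the contribution of each remains unseparated. Going by these compounds, it also remains open how a phenyl ring or a piperidine would read at this aromatic carbon.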